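Sulfur for oxygen at the aryl linker, compound 4

The source may report more compounds than this note shows. Statements on the series, on what has been measured and on what is new or still open speak of the compounds shown alone.

The three measured compounds share one core. Compound 1 `Nc1cc(N)c2nc(-c3ccccc3)c(Oc3ccc(Cl)c(Cl)c3)nc2c1` carries a 3,4-dichlorophenoxy group, and in a functional assay on NCI-H522 cells (Homo sapiens) for inhibition, read by sulforhodamine B assay, with a stated time of 48 h (a lower number here means a stronger inhibitor of growth, a higher number a weaker inhibitor of growth), compound 1 gives 33900 nM. Compound 2 `COc1ccc(Sc2nc3cc(N)cc(N)c3nc2-c2ccccc2)cc1` carries a (4-methoxyphenyl)sulfanyl group in its place. In this assay compound 2 gives only a limit, < 100000 nM. Compound 3 `Nc1cc(N)c2nc(-c3ccccc3)c(Oc3ccc(F)cc3)nc2c1` carries a 4-fluorophenoxy group. In this assay compound 3 likewise gives only a limit, < 100000 nM, so its standing is not fixed as a number. The steps a step that the limit leaves unreadable from compound 1 to compound 3 and a step that the two limits leave unreadable from compound 2 to compound 3 are accordingly unreadable, and so is a step that the limit leaves unreadable from compound 1 to compound 2. The one firm point is the limit of < 100000 nM in this assay, at which 2 of the 3 values shown sit.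

Compound 4 `Nc1cc(N)c2nc(-c3ccccc3)c(Sc3ccc(F)cc3)nc2c1` is the untested sulfur analogue of compound 3: (4-fluorophenyl)sulfanyl in place of 4-fluorophenoxy on an aromatic carbon. Within the data shown here, no measured pair isolates sulfur against oxygen with the aryl group held constant; compound 2 against compound 3 changes both the linker atom and the aryl substituent, and both values are limits. The measured steps give no readable size or direction for this change. Compound 4 is therefore expected to stay in the region of compound 3, and most likely to return only a limit itself. For compound 4 the expected step is a step that the limit leaves unreadable from compound 3 to compound 4. In this assay compound 4 is estimated at 50000 nM, within 15000 nM to 100000 nM.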

Compound 4, concentration for total growth inhibition: < 100000 nM
Compound 4 gave a limit, no number; the forecaster's own chance of this, stated with the estimate: 55%; the middle value lies beyond the limit too.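

In this assay compound 4 gives only a limit, < 100000 nM, so the steps joining compound 4 to compound 1, compound 2 and compound 3 cannot be read. The compounds shown leave open the size and direction of the change from 4-fluorophenoxy to (4-fluorophenyl)sulfanyl, and of every other change in the series: the limit of < 100000 nM in this assay, at which 3 of the 4 values shown sit.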